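Methyl for dichloro on the coumarin chalcone arm

The source may report more compounds than this note shows. Statements on the series, on what has been measured and on what is new or still open speak of the compounds shown alone.

The series shares a core carrying a styryl ketone arm, seen in compound 1 `COc1ccc(/C=C/C(=O)c2cc3ccc(OCc4cccc(OC)c4)cc3oc2=O)cc1`, in compound 2 `COC(=O)c1ccc(/C=C/C(=O)c2cc3cc(O)ccc3oc2=O)cc1` and in compound 3 `COc1cccc(COc2ccc3cc(C(=O)/C=C/c4ccc(Cl)cc4Cl)c(=O)oc3c2)c1`. In a functional assay on K562 cells (Homo sapiens) for cytotoxicity, read by MTT assay, with a stated time of 72 h (on this read-out higher numbers stand for weaker inhibition and lower numbers for stronger inhibition), compound 1 gives > 100000 nM, which is a limit of the assay and not a number. In this assay compound 2 gives 15800 nM. In this assay, among the measured compounds shown here, compound 3 gives "not determined" (no result reported), so no result is available for it; the only guidance comes from the remaining values, where the limit of > 100000 nM in this assay, at which 1 of the 3 values shown sits, marks the edge at which compound 1 sits and compound 2 stands alone as the one finite number.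

Compound 4 `COc1cccc(COc2ccc3cc(C(=O)/C=C/c4ccc(C)cc4)c(=O)oc3c2)c1` differs from compound 3 by 4-methylphenyl in place of 2,4-dichlorophenyl on a double-bonded chain carbon bound to a double-bonded chain carbon. Since no step between measured compounds is shown, the size and direction of this change cannot be read from the data, and compound 3 itself offers no anchor. The closest relative with the same benzyloxy substituent on the core is compound 1, which reaches only the limit in this assay; compound 2, with a free hydroxyl instead, lands at a finite value. On that basis compound 4 is expected to lie near the weak end, estimated at 60000 nM with a range from 15000 nM to 150000 nM, and a limit rather than a number is a real possibility.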

Compound 4, half-maximal inhibitory concentration: > 50000 nM
Compound 4: only a limit was reported (the forecaster's own chance of this, stated with the estimate: 45%); the middle value lies beyond the limit too.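

In this assay compound 4 gives > 50000 nM, which is a limit and not a number. Compound 1 also stands at a limit, > 100000 nM. The step between compound 1 and compound 4 therefore cannot be read. The compounds shown leave open whether 4-methylphenyl in place of 2,4-dichlorophenyl shifts the read-out at all.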